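The compounds below may be only part of what the source reports. "The series", "measured", "known", "first", "only" and "open" are said of these compounds alone.

In a functional assay on M14 cells (Homo sapiens) for inhibition, read by sulforhodamine B assay, with a stated time of 48 h (a higher number here means a weaker inhibitor of growth, a lower number a stronger inhibitor of growth), compound 2 `Nc1cc(N)c2nc(-c3ccccc3)c(NCc3ccc(Cl)c(Cl)c3)nc2c1` gives 15800 nM, the lowest of the three numbers in hand. Compound 3 `CCOC(=O)[C@H](CCC(=O)O)NC(=O)c1ccc(Oc2nc3cc(N)cc(N)c3nc2-c2ccccc2)cc1` gives 39800 nM, and compound 1 `CCOC(=O)[C@H](CCC(=O)O)NC(=O)c1ccc(CNc2nc3cc(N)cc(N)c3nc2-c2ccccc2)cc1` gives 45700 nM; both gaps to compound 2 lie beyond the usual scatter, so compound 2 is the strongest inhibitor of growth of the three. Compound 4 `COc1ccc(CNc2nc3cc(N)cc(N)c3nc2-c2ccccc2)cc1` has not yet been measured. It differs from compound 2 in one place: 4-methoxyphenyl in place of 3,4-dichlorophenyl on a saturated chain carbon bound to a nitrogen on an aromatic ring. Among the measured compounds shown here, no measured pair isolates this change, so its effect cannot be read from the data and is only guessed. A modest weakening of growth inhibition is expected, a step of a 1.9-fold higher number from compound 2 to compound 4 (0.28 log units; within the scatter), close to the edge of the scatter. Compound 4 is therefore estimated to give 30000 nM in this assay, with a plausible range from 12000 nM to 80000 nM.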

Compound 4, concentration for 50% growth inhibition: 18200 nM
Compound 4: middle estimate off by 1.6-fold (0.22 log units), on the high side; the range from low to high includes it.
By their numbers in this assay, from the lowest: compounds 2 and 4 (each within the scatter of the next); then compounds 3 and 1 (each within the scatter of the next).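

In this assay, putting 4-methoxyphenyl in place of 3,4-dichlorophenyl on this saturated chain carbon gives a 1.2-fold higher number from compound 2 to compound 4 (0.06 log units; within the scatter), so the two groups cannot be told apart here. The entering group has a hydrogen-bond acceptor and the leaving group has none, yet the numbers remain within the usual scatter. Nothing in hand explains why these two groups read alike. Still open, as far as these compounds go, is whether a phenyl carrying a carboxylic acid or an amine, or a longer chain at this place, would also stay within the scatter.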